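Swapping a small ring amine for a larger cyclohexyl-pyrrolidine

A few compounds are considered here, and "the series" means these few. Any claim that something is new, unique, unknown or untested is made for them only; others in the source may bear on it.

Compound 1 `N[C@H]1CC[C@H](Nc2ccc3ncc(-c4cnc(NCc5ccccn5)nc4)n3n2)CC1`: 0.4
Compound 2 `Cc1ccc2ncc(-c3cnc(Nc4ncccc4F)nc3)n2n1`: 2.5
Compound 3 `Fc1cccnc1Nc1ncc(-c2cnc3ccc(N[C@H]4CCNC4)nn23)cn1`: 0.4

In a physicochemical assay for lipophilicity (on this read-out lower numbers stand for lower lipophilicity and higher numbers for higher lipophilicity), compound 3 gives 0.4, level with compound 1 and together the lowest of the three. Within the data shown here, compound 2 gives 2.5, and the only step between compounds differing in one place is a number 2.10 log units lower from compound 2 to compound 3 (beyond the scatter). Compound 4 `Fc1cccnc1Nc1ncc(-c2cnc3ccc(N[C@H]4CC[C@H](N5CCCC5)CC4)nn23)cn1` is compound 3 with 4-(pyrrolidin-1-yl)cyclohexyl in place of pyrrolidin-3-yl on a nitrogen on an aromatic ring. Among the measured compounds shown here, no measured step describes this exact change; the only guide is that the ring amine of compound 3 sits at the low end, while compound 1, with its aminocyclohexyl group, gives 0.4. Compound 4 keeps an amine but carries more carbon and loses one donor, so it is expected to move upward: a number 1.20 log units higher from compound 3 to compound 4 (beyond the scatter). Compound 4 is thus estimated at 1.6, within 0.8 to 2.4.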

Compound 4, distribution coefficient: 1.9
Estimate against measurement, compound 4: 0.30 log units below, and the stated range covers the measured number.
By their numbers in this assay, from the lowest: compounds 1 and 3 (each within the scatter of the next); then compound 4; then compound 2.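

In this assay, 4-(pyrrolidin-1-yl)cyclohexyl in place of pyrrolidin-3-yl gives a number 1.50 log units higher from compound 3 to compound 4 (beyond the scatter), so this position responds strongly even when one ring-bearing amine group replaces another, not only when methyl is replaced. The entering group has more heavy atoms and no hydrogen-bond donor, and these differences arrive together, so this single step cannot divide the rise between them. No available evidence explains the rise. Still open, from the compounds shown here alone, is how much belongs to the cyclohexyl ring and how much to the pyrrolidine; a plain cyclohexyl group or a 4-(morpholin-4-yl)cyclohexyl group at this position would help separate them.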